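The source may report more compounds than this note shows. Statements on the series, on what has been measured and on what is new or still open speak of the compounds shown alone.

Compound 1 `COc1ncnc2c1c(-c1ccsc1)cn2[C@@H]1O[C@H](CO)[C@@H](O)[C@H]1O` gives 3350 nM in a functional assay on HeLa S3 cells (Homo sapiens) for antiproliferative activity, read by XTT assay, with a stated time of 72 h; a lower number here means a stronger inhibitor, a higher number a weaker inhibitor. Compound 2 `Cc1nc(N)c2c(-c3ccccc3)cn([C@@H]3O[C@H](CO)[C@@H](O)[C@H]3O)c2n1` reaches only the limit > 20000 nM. Compound 3 `Nc1nc(N)c2c(-c3ccccc3)cn([C@@H]3O[C@H](CO)[C@@H](O)[C@H]3O)c2n1` likewise reaches only the limit > 20000 nM.

Compound 2 thus stands at the limit of > 20000 nM in this assay, at which 2 of the 3 values shown sit, so no number is known for it. Compound 4 `Cc1nc(N)c2c(-c3ccsc3)cn([C@@H]3O[C@H](CO)[C@@H](O)[C@H]3O)c2n1` differs from compound 2 by thiophen-3-yl in place of phenyl on an aromatic carbon. Among the measured compounds shown here, the one measured step that touches compound 2, a step that the two limits leave unreadable from compound 2 to compound 3, changes a different place and its size cannot be read. For the measured compounds named here, compound 1 also carries thiophen-3-yl but differs from compound 4 in more than one place, so its value shows only that such a compound can be measured. For compound 4 the expected value is therefore 15000 nM, within 3000 nM to 60000 nM, which would mean the expected step of an at least 1.3-fold lower number from compound 2 to compound 4 (0.12 log units; that floor lies within the scatter).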

Compound 4, half-maximal inhibitory concentration: > 20000 nM
Compound 4: a limit, no number; the forecaster's own chance of this, stated with the estimate: 55%; middle value at least 1.3-fold (0.12 log units) from the limit.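

Compound 4 reaches only the limit > 20000 nM and compound 2 also stands at a limit, so the step between them cannot be read. In this assay, as far as these compounds go, it stays open whether thiophen-3-yl in place of phenyl changes the value at all.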